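Ethoxy to isopropoxy on the quinoline-type core of compound 3

The source may hold more compounds than are shown below. What is called first, only, known or untested is meant among the compounds shown, and "the series" means these compounds.

Measured in a functional assay on CV-1 cells for agonist activity at Bile acid receptor (Homo sapiens), read by a luciferase reporter; on this read-out lower numbers stand for an effect already at smaller amounts and higher numbers for an effect only at larger amounts of compound:
compound 1 `CC(C)c1onc(-c2c(Cl)cccc2Cl)c1COc1ccc(-c2ccc3nc(C(=O)O)cc(O)c3c2)cc1` gives 10000 nM
compound 2 `CCc1cc(C(=O)O)nc2ccc(-c3ccc(OCc4c(-c5c(Cl)cccc5Cl)noc4C(C)C)cc3)cc12` gives 32 nM
compound 3 `CCOc1cc(C(=O)O)nc2ccc(-c3ccc(OCc4c(-c5c(Cl)cccc5Cl)noc4C(C)C)cc3)cc12` gives 14 nM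

Compound 3 stands lowest of the three numbers in this assay. Its nearest neighbour is compound 2, separated by the modest step of a 2.3-fold lower number from compound 2 to compound 3 (0.36 log units; beyond the scatter); its furthest is compound 1, separated by the large step of a 710-fold lower number from compound 1 to compound 3 (2.85 log units; beyond the scatter). The step of a 310-fold lower number from compound 1 to compound 2 (2.49 log units; beyond the scatter) is likewise large.

Compound 4 `CC(C)Oc1cc(C(=O)O)nc2ccc(-c3ccc(OCc4c(-c5c(Cl)cccc5Cl)noc4C(C)C)cc3)cc12` differs from compound 3 by methyl in place of hydrogen on a saturated chain carbon bound to an oxygen on an aromatic ring and a saturated chain carbon. Going by the values given here, no measured pair tests a methyl added at this chain carbon, so the change is not directly covered. Among the compounds with values here, the steps that bear on it, a 710-fold lower number from compound 1 to compound 3 (2.85 log units; beyond the scatter) and a 2.3-fold lower number from compound 2 to compound 3 (0.36 log units; beyond the scatter), both end at the ethoxy-bearing compound 3 and show the alkoxy group at this position holding the lowest number so far. Keeping an alkoxy group and only lengthening it is therefore expected to give a step of no change at the digits printed from compound 3 to compound 4 (within the scatter) in this assay, not beyond the scatter in either direction. For compound 4 the estimate is 14 nM, with a range of 5 nM to 45 nM.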

Compound 4, half-maximal effective concentration: 14 nM
Beside the measured number, compound 4's estimate shows no gap at the digits printed; low and high end bracket the measured number.
By their numbers in this assay, from the lowest: compounds 3 and 4 (each within the scatter of the next); then compound 2; then compound 1.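

In this assay, going by these compounds alone, the added methyl on the saturated chain carbon is the first change at this alkoxy group, and it gives no change at the digits printed from compound 3 to compound 4 (within the scatter), so ethoxy to isopropoxy leaves the number in place. The branched group keeps the whole advantage seen with ethoxy, with a 2.3-fold lower number from compound 2 to compound 4 (0.36 log units; beyond the scatter) and a 710-fold lower number from compound 1 to compound 4 (2.85 log units; beyond the scatter), so that advantage is not confined to the ethoxy chain. Nothing available gives a reason for this flat response to the added methyl.

The compounds shown leave open how far this tolerance extends, since a longer chain such as butoxy or a bulkier group such as tert-butoxy could behave differently. Also open, as far as these compounds go, is whether the ether oxygen is needed, which an amine such as ethylamino at the same place would test.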